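Three Aryl Exchanges and One Still Unmeasured

The source may report more compounds than this note shows. Statements on the series, on what has been measured and on what is new or still open speak of the compounds shown alone.

Measured in a functional assay on A549 cells (Homo sapiens) for cytotoxicity, read by MTT assay, with a stated time of 48 h; on this read-out lower numbers stand for stronger inhibition and higher numbers for weaker inhibition:
- compound 1 `CC(C)=CCC/C(C)=C/CC/C(C)=C/CC[C@@H]1[C@@]2(C)CC/C(=N\OCc3cn(-c4ccc(F)cc4)nn3)C(C)(C)[C@@H]2CC[C@@]1(C)O`: 18000 nM
- compound 2 `CC(C)=CCC/C(C)=C/CC/C(C)=C/CC[C@@H]1[C@@]2(C)CC/C(=N\OCc3cn(-c4cccc(Br)c4)nn3)C(C)(C)[C@@H]2CC[C@@]1(C)O`: 11700 nM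
- compound 3 `CC(C)=CCC/C(C)=C/CC/C(C)=C/CC[C@@H]1[C@@]2(C)CC/C(=N\OCc3cn(-c4ccccc4C#N)nn3)C(C)(C)[C@@H]2CC[C@@]1(C)O`: 20000 nM

The three compounds share one core and differ only in the aryl group on an aromatic nitrogen. Compound 3, which carries 2-cyanophenyl, cannot be separated from either of the others, since a 1.1-fold higher number from compound 1 to compound 3 (0.05 log units; within the scatter) and a 1.7-fold higher number from compound 2 to compound 3 (0.23 log units; within the scatter) both stay within the scatter.

Compound 4 `CC(C)=CCC/C(C)=C/CC/C(C)=C/CC[C@@H]1[C@@]2(C)CC/C(=N\OCc3cn(-c4ccc(F)c(Cl)c4)nn3)C(C)(C)[C@@H]2CC[C@@]1(C)O` has 3-chloro-4-fluorophenyl in place of 2-cyanophenyl on an aromatic nitrogen. For the measured compounds named here, no measured compound carries this exact group, but all three measured steps are exchanges at this same place. Besides the two above, the third is a 1.5-fold lower number from compound 1 to compound 2 (0.19 log units; within the scatter), which is also within the scatter. With no exchange so far moving the number beyond the scatter, no step beyond the scatter is expected in this assay.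

The expected change is a 1.3-fold lower number from compound 3 to compound 4 (0.12 log units; within the scatter). For compound 4 the estimated value is 15000 nM, with an expected range from 8000 nM to 28000 nM.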

Compound 4, half-maximal inhibitory concentration: 21400 nM
Compound 4: the middle estimate sits 1.4-fold (0.15 log units) below what was measured; the range from low to high includes it.
By their numbers in this assay, from the lowest: compounds 2, 1, 3 and 4 (each within the scatter of the next).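

In this assay the exchange of 2-cyanophenyl for 3-chloro-4-fluorophenyl removes the nitrile and brings in two halogens, yet it amounts to only a 1.1-fold higher number from compound 3 to compound 4 (0.03 log units; within the scatter) and the exchange against the bromo compound to a 1.8-fold higher number from compound 2 to compound 4 (0.26 log units; within the scatter). Adding a second substituent to the aryl ring, which no earlier compound carried, also stays small, with chloro in place of hydrogen giving a 1.2-fold higher number from compound 1 to compound 4 (0.08 log units; within the scatter), so all four aryl groups at this position remain inseparable in this assay. No measurement is available that would explain why these aryl groups read alike. As far as these compounds go, it remains open whether an aryl ring carrying an amine or a carboxylic acid, or a simple alkyl chain in place of the aryl ring, would move the number beyond the scatter. Because every compound shown keeps the shared core, the effect of changes elsewhere is also unknown.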